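From Benzyl to Pyridin-4-yl on the Amide Nitrogen

The source may report more compounds than this note shows. Statements on the series, on what has been measured and on what is new or still open speak of the compounds shown alone.

Compound 1 `O=C(NCc1ccccc1)c1c(O)c2cccnc2n(-c2ccccc2)c1=O` is one member of a set of three measured in a functional assay on the whole organism for inhibition, with Rattus norvegicus as the target, read by cytopathic effect and paw edema, at a dose of 100 mg/kg by the oral route (on this read-out lower numbers stand for less inhibition and higher numbers for more inhibition at the one dose given (going by the name of the read-out)), where compound 1 gives 11.3%. Its nearest neighbour is compound 2 `O=C(Nc1cccc(Cl)c1)c1c(O)c2cccnc2n(-c2ccccc2)c1=O`, which in this assay gives 13.4%; the furthest is compound 3 `O=C(Nc1cccnc1)c1c(O)c2cccnc2n(-c2ccccc2)c1=O`, which in this assay gives 30.8%. The two steps away from compound 1 differ in size: a number 2.1 percentage points higher from compound 1 to compound 2 (within the scatter), whereas a number 19.5 percentage points higher from compound 1 to compound 3 (beyond the scatter). Between the two substituted analogues, a number 17.4 percentage points higher from compound 2 to compound 3 (beyond the scatter).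

Compound 4 `O=C(Nc1ccncc1)c1c(O)c2cccnc2n(-c2ccccc2)c1=O` is not yet measured in this assay. Relative to compound 1 it carries the change (pyridin-4-yl in place of benzyl on an amide-type nitrogen). Going by the values given here, the step that bears most on it is the one to compound 3, where a pyridin-3-yl entered in the same place, because a number 19.5 percentage points higher from compound 1 to compound 3 (beyond the scatter); the step to compound 2 is within the scatter and gives no direction. A pyridin-4-yl is expected to behave more like the pyridin-3-yl than the benzyl, so the expected step is a number 14.7 percentage points higher from compound 1 to compound 4 (beyond the scatter). Compound 4 is therefore estimated at 26%, within a range from 12% to 40%.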

Compound 4, a percentage reported as inhibition, in the whole organism at one dose (the size of the read-out at that dose, not a potency): 24.3%
Beside the measured number, compound 4's estimate is 1.7 percentage points above it; measured number inside the range.
By their numbers in this assay, from the lowest: compounds 1 and 2 (each within the scatter of the next); then compounds 4 and 3 (each within the scatter of the next).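

Compound 4 shows that the rise seen with pyridin-3-yl on the amide-type nitrogen in this assay is not confined to that one group: there is a number 13 percentage points higher from compound 1 to compound 4 (beyond the scatter) and also a number 10.9 percentage points higher from compound 2 to compound 4 (beyond the scatter). The two pyridine groups cannot be told apart here, with a number 6.5 percentage points lower from compound 3 to compound 4 (within the scatter), so moving the ring nitrogen from one to the other makes no difference that this read-out can resolve. Among these four compounds, both pyridine-bearing amides stand clear of the benzyl and 3-chlorophenyl amides, and none goes against this.

No data given here account for this separation. Still open, on these data alone, is where pyridin-2-yl would fall, and whether a phenyl ring carrying an amine or a carboxylic acid on this nitrogen would group with the pyridines or with the 3-chlorophenyl amide.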